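Swapping 2-methoxyphenyl for 4-methoxyphenyl on the side chain

The compounds below may be only part of what the source reports. "The series", "measured", "known", "first", "only" and "open" are said of these compounds alone.

Of the compounds shown here, three sharing one core have been tested in a functional assay on HT-29 cells (Homo sapiens) for inhibition, read by MTT assay, with a stated time of 3 days; on this read-out lower numbers stand for stronger inhibition and higher numbers for weaker inhibition. There compound 1 `C=CCOc1cc(/C=C\c2cc(OC)c(OC)c(OC)c2)ccc1OC` gives 29000 nM, compound 2 `COc1ccc(COc2cc(/C=C\c3cc(OC)c(OC)c(OC)c3)ccc2OC)cc1` gives 47000 nM and compound 3 `COc1ccccc1/C=C/CCCOc1cc(/C=C\c2cc(OC)c(OC)c(OC)c2)ccc1OC` gives 86000 nM. Compound 3 carries the highest of these three numbers, but only compound 1 is clearly separated from it: the measured steps are a 3.0-fold higher number from compound 1 to compound 3 (0.47 log units; beyond the scatter) and a 1.8-fold higher number from compound 2 to compound 3 (0.26 log units; within the scatter).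

Compound 4 `COc1ccc(/C=C/CCCOc2cc(/C=C\c3cc(OC)c(OC)c(OC)c3)ccc2OC)cc1` has the same atoms as compound 3, joined differently: 4-methoxyphenyl in place of 2-methoxyphenyl on a double-bonded chain carbon bound to a double-bonded chain carbon. Here 4-methoxyphenyl stands in place of 2-methoxyphenyl on a double-bonded chain carbon bound to a double-bonded chain carbon.

Among the compounds with values here, no measured step tests this exact swap. The closest evidence comes from whole-group replacements in the same side chain: a 1.6-fold higher number from compound 1 to compound 2 (0.21 log units; within the scatter), plus the two steps already given. None of these three exceeds a modest size, so no step beyond the scatter is expected in this assay, in either direction. The expected step is a 1.1-fold lower number from compound 3 to compound 4 (0.06 log units; within the scatter). For compound 4 the estimated value is 75000 nM, with an expected range from 35000 nM to 160000 nM.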

Compound 4, half-maximal inhibitory concentration: 47000 nM
Compound 4: the middle estimate sits 1.6-fold (0.20 log units) above what was measured, and the stated range covers the measured number.
By their numbers in this assay, from the lowest: compounds 1, 2, 4 and 3 (each within the scatter of the next, the first and the last beyond it).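

Compound 3 and compound 4 differ only in 2-methoxyphenyl versus 4-methoxyphenyl on a double-bonded chain carbon, and in this assay this direct test gives a 1.8-fold lower number from compound 3 to compound 4 (0.26 log units; within the scatter), so the swap has no effect that can be separated from assay noise. With 4-methoxyphenyl at the end of the side chain, the longer chain also stays within the scatter of both shorter groups, with no change at the digits printed from compound 2 to compound 4 (within the scatter) and a 1.6-fold higher number from compound 1 to compound 4 (0.21 log units; within the scatter), whereas compound 3 was clearly separated from compound 1. Nothing among the data shown offers an explanation for these numbers.

Going by these compounds, whether a side chain ending in an amine or a carboxylic acid would shift the number beyond the scatter remains open. So does the effect of a longer chain.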